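Swapping Methoxy for Bromo on the Hydrazone Aryl Ring

A few compounds are considered here, and "the series" means these few. Any claim that something is new, unique, unknown or untested is made for them only; others in the source may bear on it.

Compound 1 `COc1cccc(/C=N/NC(=O)c2ccc(C)cc2O)c1`: 20600 nM
Compound 2 `Cc1ccc(C(=O)N/N=C/c2ccccc2F)c(O)c1`: 42100 nM
Compound 3 `Cc1ccc(C(=O)N/N=C/c2cc(Br)cc(Br)c2O)c(O)c1`: 2020 nM

Of the compounds shown here, three have been tested in a functional assay (Mus musculus, strain BALB/C) for inhibition, read by MTT assay, with stated times of 24 h and 72 h; a higher number here means a weaker inhibitor, a lower number a stronger inhibitor. Compound 1 gives 20600 nM, the second highest of the three numbers; compound 2 stands higher, beyond the scatter, and compound 3 stands far lower, also beyond the scatter.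

Compound 4 `Cc1ccc(C(=O)N/N=C/c2cccc(Br)c2)c(O)c1` is not yet measured. It differs from compound 1 in a single place: bromo in place of methoxy on an aromatic carbon. Among the measured compounds shown here, no measured pair shows this exact change, so its size must be guessed. Compound 3, which carries bromo groups, gives 2020 nM, yet it also differs from compound 1 elsewhere, so it is only a weak hint.

The step of a 1.7-fold lower number from compound 1 to compound 4 (0.23 log units; within the scatter) is expected to be small, toward a lower number, and possibly within the scatter. Compound 4 is estimated at 12000 nM, within a range of 4000 nM to 40000 nM.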

Compound 4, half-maximal inhibitory concentration: 28300 nM
Beside the measured number, compound 4's estimate is 2.4-fold (0.37 log units) below it; the measured number falls inside the stated range.
By their numbers in this assay, from the lowest: compound 3; then compounds 1, 4 and 2 (each within the scatter of the next, the first and the last beyond it).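

In this assay, bromo in place of methoxy on this aromatic carbon, meta to a large group, gives a 1.4-fold higher number from compound 1 to compound 4 (0.14 log units; within the scatter) and so offers no sign that the two groups differ here. This direct comparison also shows that the change, which removes a hydrogen-bond acceptor, does not shift the number beyond the scatter. Nothing measured here offers an explanation for this result.

Still open, going by these compounds, is whether an amine or a carboxylic acid on this carbon would give a number clearly different from that of compound 1.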